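From compound 3 to compound 4: azepan-1-yl on thiocarbonyl carbon

A few compounds are considered here, and "the series" means these few. Any claim that something is new, unique, unknown or untested is made for them only; others in the source may bear on it.

In a toxicity assay on HeLa cells (Homo sapiens) for cytotoxicity, read by MTT assay, with a stated time of 24 h (on this read-out higher numbers stand for weaker inhibition and lower numbers for stronger inhibition), compound 1 `CCN1CCN(C(=S)SCC(O)Cn2c([N+](=O)[O-])cnc2C)CC1` gives > 5000000 nM, which is a limit of the assay and not a number. Compound 2 `Cc1ncc([N+](=O)[O-])n1CC(O)CSC(=S)N1CCCC1` gives 1340000 nM. Compound 3 `Cc1ncc([N+](=O)[O-])n1CC(O)CSC(=S)N1CCC(C)CC1` gives 1820000 nM. The gap between these last two values lies within the scatter: a 1.4-fold higher number from compound 2 to compound 3 (0.13 log units; within the scatter).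

Compound 4 `Cc1ncc([N+](=O)[O-])n1CC(O)CSC(=S)N1CCCCCC1` carries azepan-1-yl in place of 4-methylpiperidin-1-yl on a thiocarbonyl carbon.

Among the measured compounds shown here, the closest precedent is the exchange of pyrrolidin-1-yl for 4-methylpiperidin-1-yl, which gave a 1.4-fold higher number from compound 2 to compound 3 (0.13 log units; within the scatter). The larger steps, an at least 3.7-fold lower number from compound 1 to compound 2 (0.57 log units; beyond the scatter) and an at least 2.7-fold lower number from compound 1 to compound 3 (0.43 log units; beyond the scatter), both start from a limit and both remove 4-ethylpiperazin-1-yl, a group not involved in the present change, so they bear on it less directly. No step beyond the scatter is therefore expected in this assay, and the expected step is a 1.1-fold lower number from compound 3 to compound 4 (0.06 log units; within the scatter). The estimated value for compound 4 is 1600000 nM, with an expected range of 800000 nM to 3200000 nM.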

Compound 4, half-maximal inhibitory concentration: 411000 nM
For compound 4 the middle estimate is 3.9-fold (0.59 log units) above the measured one, outside the stated range (below it).
By their numbers in this assay, from the lowest: compound 4; then compounds 2 and 3 (each within the scatter of the next). At a limit, above all of these: compound 1.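

In this assay the exchange at the thiocarbonyl carbon now moves the number beyond the scatter between two true values: azepan-1-yl in place of 4-methylpiperidin-1-yl, with the same atoms joined differently, gives a 4.4-fold lower number from compound 3 to compound 4 (0.65 log units; beyond the scatter), and azepan-1-yl in place of pyrrolidin-1-yl gives a 3.3-fold lower number from compound 2 to compound 4 (0.51 log units; beyond the scatter). Compound 2 and compound 3 had stayed within the scatter of each other, so compound 4 is the one amine among these that separates from the others. The widest gap in the series is an at least 12-fold lower number from compound 1 to compound 4 (1.08 log units; beyond the scatter), but it is only a bound, since compound 1 gives a limit of the assay and not a number: the limit of > 5000000 nM in this assay, at which 1 of the 4 values shown sits.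

From the compounds shown here alone, whether the lower number follows ring size or the absence of the ring methyl remains open, and unsubstituted piperidin-1-yl would separate the two. Going by these compounds, whether it continues with a larger ring such as azocan-1-yl also remains open.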